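This account rests on a few compounds, and the source may have more. Where it says the series, first, only, none or still open, it means among the compounds named here.

Values in a functional assay on MCF7 cells (Homo sapiens) for antiproliferative activity, read by sulforhodamine B assay, with a stated time of 48 h; on this read-out lower numbers stand for stronger inhibition and higher numbers for weaker inhibition:
- Compound 1 `O=C1NCCN1c1ccc(S(=O)(=O)Nc2ccc(C3CCCCC3)cc2)cc1`: > 1000 nM (a limit, not a number)
- Compound 2 `CCc1ccc(NS(=O)(=O)c2ccc(N3CCNC3=O)cc2)cc1`: 810 nM
- Compound 3 `CC(C)(C)c1ccc(NS(=O)(=O)c2ccc(N3CCNC3=O)cc2)cc1`: > 1000 nM (a limit, not a number)

Compound 3 gives only a limit, > 1000 nM, so it has no exact place in the set. Its position is the limit of > 1000 nM in this assay, at which 2 of the 3 values shown sit. Among the compounds with values here, compound 2 gives 810 nM, the only actual number here.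

Compound 4 `CC(C)Cc1ccc(NS(=O)(=O)c2ccc(N3CCNC3=O)cc2)cc1` carries isobutyl in place of tert-butyl on an aromatic carbon and keeps the rest of compound 3 unchanged.

Three measured steps changed the group at this same place. Going to tert-butyl from ethyl gave an at least 1.2-fold higher number from compound 2 to compound 3 (0.09 log units; that floor lies within the scatter). Going to ethyl from cyclohexyl gave an at least 1.2-fold lower number from compound 1 to compound 2 (0.09 log units; that floor lies within the scatter). Going to tert-butyl from cyclohexyl gave a step that the two limits leave unreadable from compound 1 to compound 3. Within the data shown here, none of them shows a change beyond the scatter, so no step of that size and no particular direction is expected in this assay for this swap.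

The estimated step is a number no higher from compound 3 to compound 4 (the limit leaves the size open), and the assay may again report only a limit. For compound 4 the expected value is 1000 nM, with an estimated range from 450 nM to 2500 nM.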

Compound 4, half-maximal inhibitory concentration: > 1000 nM
Compound 4 was reported as a limit; the forecaster's own chance of this, stated with the estimate: 55%; the middle value lies on the limit itself.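

In this assay compound 4 gives > 1000 nM, a limit and not a number, so isobutyl, made of the same atoms as tert-butyl joined differently, joins the groups that reach this limit: the limit of > 1000 nM in this assay, at which 3 of the 4 values shown sit.

Within the data shown here, the only readable comparison is an at least 1.2-fold higher number from compound 2 to compound 4 (0.09 log units; that floor lies within the scatter), so it does not establish a real loss of activity. The steps to compound 4 from compound 1 and from compound 3 cannot be read, as both ends of each are limits.

Among these compounds, how far compound 1, compound 3 and compound 4 truly lie from the one exact value remains open. From the compounds shown here alone, it is also open whether a methyl group, a longer straight chain or an amine at this place would give a clearly lower number.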